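Methoxy to hydroxy: one change in a cytotoxicity series

This account rests on a few compounds, and the source may have more. Where it says the series, first, only, none or still open, it means among the compounds named here.

Measured compounds:
Compound 1 `COc1cc(C)cc(-c2c(-c3ccnc(-c4ccc(N(C)C)cc4)c3)cnn2CC#N)c1`: 95%
Compound 2 `COc1cc(C)cc(-c2nn(CC#N)cc2-c2ccnc(-c3ccc(N(C)C)cc3)c2)c1`: 97%
Compound 3 `COc1cc(C)cc(-c2nn(CC#N)cc2-c2ccc(-c3cccc(C(C)=O)c3)nc2)c1`: 97%

In a functional assay on A549 cells (Homo sapiens) for cytotoxicity, read by sulforhodamine B assay, with a stated time of 48 h, tested at 0.001 uM (on this read-out lower numbers stand for a stronger effect and higher numbers for a weaker effect at the one concentration tested), compound 2 gives 97%, level with compound 3 at the digits shown, and these two stand together as the highest of the three numbers. Compound 1 differs from compound 2 by an amount within the scatter, so no order can be read among the three.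

Compound 4 `Cc1cc(O)cc(-c2nn(CC#N)cc2-c2ccnc(-c3ccc(N(C)C)cc3)c2)c1` differs from compound 2 by hydrogen in place of methyl on an oxygen on an aromatic ring. Among the measured compounds shown here, no measured pair shows this change, so its effect is unknown. Since all three measured compounds sit within the scatter of one another in this assay, a step in either direction beyond the scatter is not expected. For compound 4 the estimated value is 96%, within 88% to 100%, which is expected to mean a step of a number 1 percentage points lower from compound 2 to compound 4 (within the scatter).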

Compound 4, a percentage reported as activity, at one concentration (the size of the read-out at that concentration, not a potency): 104%
Compound 4: middle estimate off by 8 percentage points, on the low side; measured number outside the range, above it.
By their numbers in this assay, from the lowest: compounds 1, 2, 3 and 4 (each within the scatter of the next).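

Among the compounds shown here, this is the first pair that differs in one place. In this assay, hydrogen in place of methyl on an oxygen on an aromatic ring, methoxy to hydroxy, gives a number 7 percentage points higher from compound 2 to compound 4 (within the scatter) and so leaves the read-out at the one concentration tested unchanged within the usual scatter. The methyl on this oxygen can therefore be exchanged for hydrogen without a step that can be read in this series.

From the compounds shown here alone, whether an ethoxy group, an amine or a carboxylic acid at this place would read the same remains open. Nothing measured here bears on why the pair reads as it does.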